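The source may hold more compounds than are shown below. What is called first, only, known or untested is meant among the compounds shown, and "the series" means these compounds.

Among the compounds with values here, in a toxicity assay on NIH3T3 cells (Mus musculus) for cytotoxicity, read by resazurin assay (a higher number here means that more compound is needed for the effect, a lower number that less compound is needed), only two compounds have been measured. Compound 1 `CC(=O)c1ccc(NCc2cncn2Cc2ccc(-c3ccccc3)cc2)cc1-c1ccccc1` gives > 10000 nM, which is a limit of the assay and not a number. That limit is the one reached so far: the limit of > 10000 nM in this assay, at which 1 of the 2 values shown sits. Within the data shown here, compound 2 `c1ccc(-c2ccc(Cn3cncc3CNc3cccc(-c4ccccc4)c3)cc2)cc1` gives 10000 nM, the only actual number available in this assay.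

The next compound, compound 3 `O=C(c1ccc(NCc2cncn2Cc2ccc(-c3ccccc3)cc2)cc1-c1ccccc1)N1CCCCC1`, is derived from compound 2 by placing (piperidin-1-yl)carbonyl in place of hydrogen on an aromatic carbon. Among the measured compounds shown here, only one measured step bears on this change. In a number no higher from compound 1 to compound 2 (the limit leaves the size open), hydrogen takes the place of acetyl on an aromatic carbon, and the limit leaves the size of that step open. Compound 3 reverses that kind of change, with a larger group, so the step offers a direction but no magnitude. On that thin basis, no change beyond the usual scatter is expected, with any drift toward a higher number. The estimated change is a 1.2-fold higher number from compound 2 to compound 3 (0.08 log units; within the scatter). For compound 3 the expected value is 12000 nM, within an estimated range from 5000 nM to 30000 nM.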

Compound 3, half-maximal effective concentration: > 1000 nM
Compound 3: no number, only a limit (the forecaster's own chance of this, stated with the estimate: 60%); the middle value does not contradict the limit.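

In this assay compound 3 gives > 1000 nM, which is a limit of the assay and not a number. The steps from compound 2 to compound 3 and from compound 1 to compound 3 therefore cannot be read. The compounds shown leave open whether (piperidin-1-yl)carbonyl in place of hydrogen changes the number in this assay at all, and by how much.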